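The compounds below may be only part of what the source reports. "The series", "measured", "known", "first", "only" and "open" are said of these compounds alone.

Working notes on the series.

Of the compounds shown here, three have been measured in a functional assay on U-87MG ATCC cells for antiproliferative activity against U-87 MG (Homo sapiens), read by MTT assay, with a stated time of 48 h, tested at 100 uM; a higher number here means a weaker effect of the compound at the concentration tested, a lower number a stronger effect. Compound 1 `COc1ccc(-c2nc(C)c(C(=O)CSc3nc(-c4ccc(OC)cc4)c(C#N)c(=O)[nH]3)s2)cc1` gives 11.5%. Compound 2 `Cc1nc(-c2ccccc2)sc1C(=O)CSc1nc(-c2ccccc2)c(C#N)c(=O)[nH]1` gives 9.23%. Compound 3 `Cc1nc(-c2ccc(Cl)cc2)sc1C(=O)CSc1nc(-c2ccccc2)c(C#N)c(=O)[nH]1` gives 11.4%. Compound 2 holds the lowest of the three numbers, but its nearest neighbour compound 3 and its furthest neighbour compound 1 both sit within the scatter of it, so no order among the three can be read from these values.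

Compound 4 `Cc1nc(-c2ccccc2)sc1C(=O)CSc1nc(-c2ccc(Cl)cc2)c(C#N)c(=O)[nH]1` is not yet measured. It differs from compound 2 by chloro in place of hydrogen on an aromatic carbon. Among the compounds with values here, the one measured step that bears on it is the step of a number 2.2 percentage points higher from compound 2 to compound 3 (within the scatter), which introduced the same chloro group on the other aromatic ring of compound 2 and stayed within the scatter. On that basis no movement beyond the scatter is expected in this assay for compound 4, and the step of a number 1.8 percentage points higher from compound 2 to compound 4 (within the scatter) is the expected result of the change. Compound 4 is therefore estimated at 11%, with a range from 4% to 20%.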

Compound 4, a percentage reported as activity, at one concentration (the size of the read-out at that concentration, not a potency): 22.5%
For compound 4 the middle estimate is 11.5 percentage points below the measured one, and the stated range ends below it.
By their numbers in this assay, from the lowest: compounds 2, 3 and 1 (each within the scatter of the next); then compound 4.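

In this assay, within the data shown here, phenyl to 4-chlorophenyl at this position, para to a large group, gives a number 13.3 percentage points higher from compound 2 to compound 4 (beyond the scatter), the first step that lies beyond the scatter, and the number moves towards a weaker effect at the concentration tested. The same change on the other aromatic ring gave only a number 2.2 percentage points higher from compound 2 to compound 3 (within the scatter), so the result of adding chloro in this series depends on which of the two rings carries it. No measurement shown here accounts for this difference between the two rings.

The compounds shown leave open whether a fluoro, an amine or a carboxylic acid in place of the chloro at this position would also raise the number. Among these compounds, with only one step at this position, they also leave open how far this result extends beyond compound 4.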